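The compounds below may be only part of what the source reports. "The series", "measured", "known", "first", "only" and "open" are said of these compounds alone.

Compound 1 `Cn1cnc2c(Sc3ccccc3)ncnc21` gives 0%
Compound 2 `CSc1ccc(-c2nc3c(Sc4ccccc4)ncnc3n2C)cc1` gives 5%
Compound 3 `Cn1c(Br)nc2c(Sc3ccccc3)ncnc21` gives 1%

All three numbers come from an assay on isolated protein for inhibition of RAC-alpha serine/threonine-protein kinase (Homo sapiens), tested at 30 uM; a lower number here means less inhibition, a higher number more inhibition at the concentration tested (going by the name of the read-out). Compound 3 stands second highest of the three, though its neighbours are close: a number 1 percentage points higher from compound 1 to compound 3 (within the scatter), and a number 4 percentage points lower from compound 2 to compound 3 (within the scatter). None of the three compounds reaches inhibition beyond the scatter at this concentration.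

The next compound, compound 4 `Cn1c(C#CCCO)nc2c(Sc3ccccc3)ncnc21`, departs from compound 3 at the same site that has been varied so far: 4-hydroxybut-1-yn-1-yl in place of bromo on an aromatic carbon. The two measured steps that bear on this site, bromo entering for hydrogen from compound 1 to compound 3 and bromo replacing 4-(methylsulfanyl)phenyl from compound 2 to compound 3, both stayed within the scatter, as did the step from compound 1 to compound 2 at that carbon. Nothing measured at this position has moved the read-out, so no step beyond the scatter is expected here either, in either direction; compound 4 is expected to show a number 2 percentage points higher from compound 3 to compound 4 (within the scatter). Compound 4 is therefore estimated at 3%, in the range 0% to 15%.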

Compound 4, a percentage reported as inhibition, at one concentration (the size of the read-out at that concentration, not a potency): 33%
The estimate for compound 4 lay 30 percentage points below the measured number; the whole stated range lies below it.
By their numbers in this assay, from the lowest: compounds 1, 3 and 2 (each within the scatter of the next); then compound 4.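

Within the data shown here, at this carbon, between two ring nitrogen atoms, a substitution now moves the read-out in this assay for the first time: 4-hydroxybut-1-yn-1-yl gives a number 32 percentage points higher from compound 3 to compound 4 (beyond the scatter), together with a number 33 percentage points higher from compound 1 to compound 4 (beyond the scatter) and a number 28 percentage points higher from compound 2 to compound 4 (beyond the scatter). Hydrogen, bromo and 4-(methylsulfanyl)phenyl all stayed within the scatter of one another, so the position responds to this particular group and not to substitution as such. Nothing available gives a reason for this rise.

The compounds shown leave open which part of the new group carries the step: the triple bond, the length of the chain or the hydroxyl. A saturated butyl chain ending in hydroxyl, the same alkyne ending in an amine or a carboxylic acid, or a longer chain would begin to separate these.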